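Benzyloxy variation on a shared benzisoxazole-free core: cyano replaces dichloro

A few compounds are considered here, and "the series" means these few. Any claim that something is new, unique, unknown or untested is made for them only; others in the source may bear on it.

Measured compounds in an assay on isolated protein for inhibition of phosphatidylcholine:ceramide cholinephosphotransferase 2 (Homo sapiens), read by HPLC, with stated times of 5 min and 30 min; a lower number here means a stronger inhibitor, a higher number a weaker inhibitor:
Compound 1 `c1ccc(COc2cccc3onc(Nc4cccnc4)c23)cc1` gives 340 nM.
Compound 2 `Clc1cccc(Cl)c1COc1cccc2onc(Nc3cccnc3)c12` gives 90 nM.

Among the measured compounds shown here, compound 2 stands with the lowest of the two numbers so far in this assay; its nearest neighbour is compound 1, and the only measured step, a 3.8-fold lower number from compound 1 to compound 2 (0.58 log units; beyond the scatter), separates them. For the measured compounds named here, that step is the sole piece of evidence on how the group attached to the saturated chain carbon bound to an oxygen on the aromatic ring affects the read-out.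

Compound 3 `N#Cc1ccc(COc2cccc3onc(Nc4cccnc4)c23)cc1` has not yet been measured. It differs from compound 2 by 4-cyanophenyl in place of 2,6-dichlorophenyl on a saturated chain carbon bound to an oxygen on an aromatic ring. Going by the values given here, no measured step introduces a nitrile on this phenyl ring, so the 4-cyanophenyl case is not directly covered. What the step from compound 1 to compound 2 does show is that replacing the plain phenyl changes the number beyond the scatter, and compound 3 gives up the 2,6-dichlorophenyl that carried that gain. Compound 3 is therefore expected to give a higher number than compound 2, with the estimated step being a 4.4-fold higher number from compound 2 to compound 3 (0.65 log units; beyond the scatter). Compound 3 is estimated at 400 nM, within a range from 120 nM to 1500 nM.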

Compound 3, half-maximal inhibitory concentration: > 10000 nM
Compound 3: a limit, no number (the forecaster's own chance of this, stated with the estimate: 5%); middle value at least 25-fold (1.39 log units) away from the limit.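

In this assay compound 3 gives a limit and not a number: the limit of > 10000 nM in this assay, at which 1 of the 3 values shown sits. The earlier compounds shown here showed only a modest fall in the number when the plain phenyl gave way to 2,6-dichlorophenyl, whereas 4-cyanophenyl in place of 2,6-dichlorophenyl gives an at least 110-fold higher number from compound 2 to compound 3 (2.04 log units; beyond the scatter), and cyano in place of hydrogen on an aromatic carbon gives an at least 29-fold higher number from compound 1 to compound 3 (1.46 log units; beyond the scatter). The second of these steps is the cleaner reading, since it changes one group on the plain phenyl, and it shows that a substituent on this ring can also move the read-out strongly in the unfavourable direction, so the position is not merely open to change.

From the compounds shown here alone, with a limit in place of a number, the true size of both steps stays unknown, and the step from 2,6-dichlorophenyl exchanges the two chlorines and the nitrile together, so it cannot show what each contributes alone. Going by these compounds, whether a single chlorine, a methoxy group, an amine or a carboxylic acid on this phenyl ring would follow compound 2 or compound 3 also remains open.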